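This account rests on a few compounds, and the source may have more. Where it says the series, first, only, none or still open, it means among the compounds named here.

Measured compounds:
Compound 1 `COc1ccc2[nH]c(-c3ccc[se]3)cc(=O)c2c1OC` gives > 100000 nM in a functional assay on Hep 3B2 cells (Homo sapiens) for cytotoxicity, read by MTT assay, with a stated time of 48 h (a higher number here means a weaker inhibitor, a lower number a stronger inhibitor), which is a limit of the assay.
Compound 2 `COc1ccc2[nH]c(-c3ccc(C)[se]3)cc(=O)c2c1OC` gives > 50000 nM in this assay, which is also a limit.

Within the data shown here, compound 2 stands at a limit in this assay, and the only other value, that of compound 1, is a limit too. Among the measured compounds shown here, the single measured step, a step that the two limits leave unreadable from compound 1 to compound 2, therefore has no readable size, as the limit of > 100000 nM in this assay, at which 1 of the 2 values shown sits, and the limit of > 50000 nM in this assay, at which 1 of the 2 values shown sits, show. Compound 3 `COc1ccc2[nH]c(-c3cc[se]c3)cc(=O)c2c1OC` differs from compound 2 by a group of 5 heavy atoms (4 carbon, 1 selenium; one five-membered aromatic ring with 1 hetero atom) in place of a group of 6 heavy atoms (5 carbon, 1 selenium; one five-membered aromatic ring with 1 hetero atom), on an aromatic carbon. For the measured compounds named here, no measured step bears on this change: the one step in the set is a methyl in place of hydrogen and is itself unreadable. With both measured compounds sitting at limits, nothing in the numbers points to a gain in potency, and compound 3 is expected to stay at or near the limit, with a step that the limit leaves unreadable from compound 2 to compound 3 as the expected step. The estimate for compound 3 is 100000 nM, between 30000 nM and 300000 nM.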

Compound 3, half-maximal inhibitory concentration: 100000 nM
Beside the measured number, compound 3's estimate shows no gap at the digits printed; measured number inside the range.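

Compound 3 gives 100000 nM in this assay, so with this five-membered aromatic ring with 1 hetero atom on the aromatic carbon next to the ring nitrogen, the series has its first number that is not a limit, with a number no higher from compound 1 to compound 3 (the limit leaves the size open) as the step on this change. The steps from compound 1 and from compound 2 to compound 3 cannot be read, because the value of compound 1 is a limit: the limit of > 100000 nM in this assay, at which 1 of the 3 values shown sits. The value of compound 2 is likewise a limit: the limit of > 50000 nM in this assay, at which 1 of the 3 values shown sits.

Still open, on these data alone, is whether any group at this aromatic carbon gives a clearly lower number in this assay, for example a phenyl ring in place of the selenium-containing ring. Also open, as far as these compounds go, is how an amine or a carboxylic acid on the selenium-containing ring would read there.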